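This account rests on a few compounds, and the source may have more. Where it says the series, first, only, none or still open, it means among the compounds named here.

In an assay on microsomes from intestine for inhibition of acyl-CoA:cholesterol acyltransferase (Oryctolagus cuniculus) (a higher number here means a weaker inhibitor, a lower number a stronger inhibitor), compound 1 `CCOC(=O)CC(=O)Nc1c(C(C)C)cccc1C(C)C` gives 1800 nM, the highest number among the three compounds measured. Among the compounds with values here, compound 2 `CC(C)c1cccc(C(C)C)c1OC(=O)CC(=O)Nc1c(N(C)C)cccc1N(C)C` gives 71 nM and compound 3 `CCCCCCCCCCCCC(C)(C)OC(=O)CC(=O)Nc1c(C(C)C)cccc1C(C)C` gives 12 nM; both gaps from compound 1 lie beyond the scatter, the one to compound 3 being the wider. Compound 4 `CCCCCCOC(=O)CC(=O)Nc1c(C(C)C)cccc1C(C)C` has not yet been measured. It differs from compound 1 by butyl in place of hydrogen on a saturated chain carbon, two bonds along the chain from an oxygen next to a carbonyl group. Within the data shown here, no measured pair shows this change alone, so the expectation rests on the numbers themselves. Because compound 3, with a longer chain on the oxygen next to the carbonyl group, gives 12 nM, a step toward a lower number, beyond the scatter, is expected. The expected step from compound 1 to compound 4 is a 12-fold lower number from compound 1 to compound 4 (1.08 log units; beyond the scatter). Compound 4 is estimated at 150 nM, within a range from 40 nM to 600 nM.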

Compound 4, half-maximal inhibitory concentration: 810 nM
Compound 4: middle estimate off by 5.4-fold (0.73 log units), on the low side; the whole stated range lies below it.
By their numbers in this assay, from the lowest: compound 3; then compound 2; then compound 4; then compound 1.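

Butyl in place of hydrogen on a saturated chain carbon, two bonds along the chain from an oxygen next to a carbonyl group, can now be read alone. In this assay it gives a 2.2-fold lower number from compound 1 to compound 4 (0.35 log units; beyond the scatter) and so shows that going from ethoxy to hexyloxy on the core of compound 1 moves the number down only modestly. Nothing available explains this step. On these data alone, whether a longer chain, or a branched one, would lower the number further remains open, as does the effect of an amine or a carboxylic acid at the chain end.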